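The source may report more compounds than this note shows. Statements on the series, on what has been measured and on what is new or still open speak of the compounds shown alone.

Working notes on the series. The shared core is kept throughout and the variation sits at the far end of the saturated ring. Compound 1 `NS(=O)(=O)N1CCC(C(=O)/C(=N/O)Nc2ccc(F)c(Br)c2)CC1` carries a sulfamoyl on the amine nitrogen in the ring; in an assay for inhibition of Indoleamine 2,3-dioxygenase 1 (Homo sapiens), with a stated time of 1 h (a lower number here means a stronger inhibitor, a higher number a weaker inhibitor), compound 1 gives 63 nM. Compound 2 `O=C(/C(=N/O)Nc1ccc(F)c(Br)c1)C1CCN(C(=O)NCc2ccccc2)CC1` carries a benzylcarbamoyl on that nitrogen instead, and in this assay compound 2 gives 43 nM. Compound 3 `O=C(NC[C@H]1CC[C@H](C(=O)/C(=N/O)Nc2ccc(F)c(Br)c2)CC1)c1ccccc1` has its structure as shown and gives 80 nM in this assay. Among the compounds with values here, the single measured step, a 1.5-fold lower number from compound 1 to compound 2 (0.17 log units; within the scatter), is the only one-place change among the three. On the numbers as they stand, compound 2 sits at the low end, but its gaps to compound 1 and to compound 3 both lie within the scatter, so the three are not distinguished.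

Compound 4 `O=C(/C(=N/O)Nc1ccc(F)c(Br)c1)C1CCN(C(=O)Nc2ccccc2)CC1` differs from compound 2 by phenyl in place of benzyl on an amide-type nitrogen. Within the data shown here, no measured step covers this exact change. The nearest guide is the step from compound 1 to compound 2, where exchanging the group on the ring amine nitrogen for a quite different one gave no movement beyond the scatter; on that basis compound 4 is expected to stay close to compound 2, with the estimated step of a 1.2-fold higher number from compound 2 to compound 4 (0.07 log units; within the scatter) falling within the scatter in either direction. For compound 4 the estimate in this assay is 50 nM, with a range of 20 nM to 130 nM.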

Compound 4, half-maximal inhibitory concentration: 40 nM
The estimate for compound 4 lay 1.3-fold (0.10 log units) above the measured number; the measured number falls inside the stated range.
By their numbers in this assay, from the lowest: compounds 4, 2, 1 and 3 (each within the scatter of the next).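

In this assay the outer group on the amide-type nitrogen can be exchanged with no movement beyond the scatter: phenyl in place of benzyl gives a 1.1-fold lower number from compound 2 to compound 4 (0.03 log units; within the scatter) and so takes the carbamoyl series from a benzyl of 7 carbon atoms to a phenyl of 6 with the aromatic ring retained. Within the data shown here, this is the first reading at this outer place, as the earlier step changed the whole group on the ring amine nitrogen. The second carbamoyl compound also stays close to the sulfamoyl compound, with a 1.6-fold lower number from compound 1 to compound 4 (0.20 log units; within the scatter) (again within the scatter), so neither benzylcarbamoyl nor phenylcarbamoyl is separated from sulfamoyl on the amine nitrogen in the ring. Nothing available bears on why these numbers stay together.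

Still open is whether any group on the amide-type nitrogen moves the number beyond the scatter, since only benzyl and phenyl are shown there. A carboxylic acid or an amine on the phenyl ring, or a longer chain between that nitrogen and the aromatic ring, would show whether this place stays as flat as these compounds suggest.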